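A Longer Bromoalkoxy Chain on the Shared Core

This account rests on a few compounds, and the source may have more. Where it says the series, first, only, none or still open, it means among the compounds named here.

Measured in a functional assay on A549 cells (Homo sapiens) for antiproliferative activity, read by MTT assay, with a stated time of 48 h; on this read-out higher numbers stand for weaker inhibition and lower numbers for stronger inhibition:
- Compound 1 `COc1ccc(N(C)c2ccnc(Cl)n2)cc1`: 611 nM
- Compound 2 `COc1ccc(N(C)c2ccnc(Cl)n2)cc1OCCCBr`: 862 nM

Going by the values given here, compound 2, at 862 nM, cannot be separated from the only other measured value, and the two stand within the usual scatter of each other.

Compound 3 `COc1ccc(N(C)c2ccnc(Cl)n2)cc1OCCCCBr` differs from it at the end of the chain: bromomethyl in place of bromo on a saturated chain carbon, three bonds along the chain from an oxygen on an aromatic ring. Cut one bond further out, the same difference reads 3-bromopropyl to 4-bromobutyl. Among the compounds with values here, no measured step lengthens a chain, so the closest evidence is the step that introduced the 3-bromopropoxy group: a 1.4-fold higher number from compound 1 to compound 2 (0.15 log units; within the scatter). Since that whole group left the value within the scatter, no change beyond the scatter is expected in this assay from this smaller extension. The expected step is a 1.0-fold lower number from compound 2 to compound 3 (0.01 log units; within the scatter). For compound 3 the estimated value is 850 nM, with an expected range from 400 nM to 1800 nM.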

Compound 3, half-maximal inhibitory concentration: 591 nM
For compound 3 the middle estimate is 1.4-fold (0.16 log units) above the measured one; the measured number falls inside the stated range.
By their numbers in this assay, from the lowest: compounds 3, 1 and 2 (each within the scatter of the next).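

In this assay, lengthening the 3-bromopropyl chain to 4-bromobutyl gives a 1.5-fold lower number from compound 2 to compound 3 (0.16 log units; within the scatter), so this first test of chain length at this position shows no separable effect from the added carbon. Placing the whole 4-bromobutoxy group on the aromatic carbon that carries hydrogen in the shared core gives a 1.0-fold lower number from compound 1 to compound 3 (0.01 log units; within the scatter), so both the 3-bromopropoxy and the 4-bromobutoxy group now leave the value within the scatter of the unsubstituted compound. The available data offer no independent measurement that bears on this result.

From the compounds shown here alone, whether a longer chain would move the value beyond the scatter remains open. Going by these compounds, it is equally open whether an amine or a carboxylic acid in place of the bromo at the chain end would do so.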